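The source may hold more compounds than are shown below. What is called first, only, known or untested is meant among the compounds shown, and "the series" means these compounds.

The compounds share one core, seen in compound 1 `COc1cccc(N2CCN(C(=O)C(C)N3C(=O)CCC3=O)CC2)c1`, in which an aromatic methoxy group sits; in a functional assay on the whole organism (strain Swiss) with Mus musculus as the target, in the maximal electroshock model, with a stated time of 0.5 h, at a dose of 300 mg/kg by the intraperitoneal route (on this read-out lower numbers stand for a weaker effect and higher numbers for a stronger effect at the one dose given), compound 1 gives 50%. Compound 2 `CC(C(=O)N1CCN(c2ccccc2)CC1)N1C(=O)CCC1=O` carries a plain phenyl ring instead, and in this assay compound 2 gives 50%, so no change at the digits printed from compound 1 to compound 2 (within the scatter). Compound 3 `CCC(C(=O)N1CCN(c2ccccc2Cl)CC1)N1C(=O)CCC1=O`, bearing both an aromatic chloro group and an ethyl chain, gives 25% in this assay, a number lower than that of compound 2. Compound 4 `CC(C(=O)N1CCN(c2ccccc2F)CC1)N1C(=O)CCC1=O` differs from compound 2 by fluoro in place of hydrogen on an aromatic carbon. For the measured compounds named here, only the step from compound 1 to compound 2 bears on a single ring change, and it showed no change; compound 3 suggests a halogen at that place may lower the number, but it differs in two places. Compound 4 is therefore expected to show a number 5 percentage points lower from compound 2 to compound 4 (within the scatter) in this assay, with compound 4 estimated at 45%, between 25% and 70%.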

Compound 4, a percentage reported as activity, at one dose (the size of the read-out at that dose, not a potency): 50%
Compound 4: the middle estimate sits 5 percentage points below what was measured; the range from low to high includes it.
By their numbers in this assay, from the lowest: compound 3; then compounds 1, 2 and 4 (each within the scatter of the next).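

In this assay fluoro on an aromatic carbon, ortho to a large group, brings no change at the digits printed from compound 2 to compound 4 (within the scatter) as a single change, the first clean test of a halogen at this place, and this halogen does not lower the number. Putting 2-fluorophenyl in place of 3-methoxyphenyl brings no change at the digits printed from compound 1 to compound 4 (within the scatter) as well, so these ring variations read alike here. No available evidence explains this. Still open, as far as these compounds go, is whether a chloro group alone would act like fluoro, or whether the ethyl chain accounts for compound 3. An amine on the ring is also untested among the compounds shown.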